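The source may report more compounds than this note shows. Statements on the series, on what has been measured and on what is new or still open speak of the compounds shown alone.

Compound 1, `Nc1nn(C(=O)Nc2ccc(Cc3ccccc3)cc2)c2ccccc12`, gives > 100000 nM in a functional assay on UACC-62 cells (Homo sapiens) for antiproliferative activity, read by sulforhodamine B assay, with a stated time of 48 h; a lower number here means that less compound is tolerated, a higher number that more compound is tolerated.
Compound 2, `Nc1nn(C(=O)Nc2ccc(Cc3ccccc3)cc2)c2ccc(Cl)cc12`, gives > 100000 nM in this assay.

For compound 1 the result is only a limit of this assay, not a measured number. For compound 2 the result is likewise only a limit, so compound 2 stands at the edge of what this assay can read, without a number of its own. Both values sit at the limit of > 100000 nM in this assay, at which 2 of the 2 values shown sit, and the step that the two limits leave unreadable from compound 1 to compound 2 therefore cannot be read in size or direction.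

Compound 3, `Nc1ccc2c(c1)c(N)nn2C(=O)Nc1ccc(Cc2ccccc2)cc1`, differs from compound 2 in one place: amino in place of chloro on an aromatic carbon. Among the compounds with values here, the only measured step, a step that the two limits leave unreadable from compound 1 to compound 2, touches the same carbon but gives no usable size. The two measured compounds show only that large amounts of either are tolerated, and one change at this carbon is not expected to move the number beyond the scatter. Compound 3 is therefore expected to give about 120000 nM, with a range from 30000 nM to 400000 nM. The estimated step that the limit leaves unreadable from compound 2 to compound 3 is expected to be small.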

Compound 3, concentration lethal to 50% of the cells: 39300 nM
Compound 3: the middle estimate sits 3.1-fold (0.48 log units) above what was measured, and the stated range covers the measured number.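

Within the data shown here, compound 3 is the first compound here with a number of its own in this assay, so this carbon of the shared core can now be seen to affect how much compound the cells tolerate. Amino in place of chloro gives an at least 2.5-fold lower number from compound 2 to compound 3 (0.40 log units; beyond the scatter), and amino in place of hydrogen gives an at least 2.5-fold lower number from compound 1 to compound 3 (0.40 log units; beyond the scatter). These steps give only the smallest possible size, because compound 1 and compound 2 both stand at the edge of what can be read: the limit of > 100000 nM in this assay, at which 2 of the 3 values shown sit.

From the compounds shown here alone, the full size of the amino effect therefore stays unknown, and so does the effect of amino at any other carbon of the core. Going by these compounds, it also stays open whether a hydroxyl, a methylamino or an acetamido group on this carbon would give a lower number, a higher one or the same.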